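Calpain-2 ketoamides: lengthening the terminal amide chain

The source may report more compounds than this note shows. Statements on the series, on what has been measured and on what is new or still open speak of the compounds shown alone.

Measured so far in an assay on isolated protein (Oryctolagus cuniculus) for inhibition of Calpain-2 catalytic subunit (Homo sapiens), at pH 8.0; a lower number here means a stronger inhibitor, a higher number a weaker inhibitor:
compound 1, `CCCCNC(=O)C(=O)C(CC)NC(=O)C(CC(C)C)NC(=O)OCc1ccccc1`: 50 nM
compound 2, `CCC(NC(=O)C(CC(C)C)NC(=O)OCc1ccccc1)C(=O)C(=O)NCC(C)C`: 140 nM
compound 3, `CCCCCCCCNC(=O)C(=O)C(CC)NC(=O)C(CC(C)C)NC(=O)OCc1ccccc1`: 19 nM

Compound 3 gives the lowest number of the three. Its nearest neighbour is compound 1, with a 2.6-fold lower number from compound 1 to compound 3 (0.42 log units; beyond the scatter); the furthest is compound 2, with a 7.4-fold lower number from compound 2 to compound 3 (0.87 log units; beyond the scatter). The remaining step, a 2.8-fold higher number from compound 1 to compound 2 (0.45 log units; beyond the scatter), runs the other way.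

Compound 4, `CCCCCCCCCCNC(=O)C(=O)C(CC)NC(=O)C(CC(C)C)NC(=O)OCc1ccccc1`, differs from compound 3 by ethyl in place of hydrogen on a saturated chain carbon, eight bonds along the chain from an amide-type nitrogen; cut one bond further out, the same difference reads ethyl to butyl. For the measured compounds named here, the steps that bear on it are those that lengthen the chain on the terminal amide nitrogen: a 2.6-fold lower number from compound 1 to compound 3 (0.42 log units; beyond the scatter) and a 7.4-fold lower number from compound 2 to compound 3 (0.87 log units; beyond the scatter), both modest, both toward lower numbers. The present change adds less than either of those, on a chain already long, so a smaller step in the same direction, or none beyond the scatter, is expected for compound 4 in this assay, as a 1.3-fold lower number from compound 3 to compound 4 (0.10 log units; within the scatter).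

The estimate for compound 4 in this assay is 15 nM, with a range from 6 nM to 40 nM.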

Compound 4, inhibition constant: 600 nM
Estimate against measurement, compound 4: 40-fold (1.60 log units) below; the whole stated range lies below it.
By their numbers in this assay, from the lowest: compound 3; then compound 1; then compound 2; then compound 4.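

In this assay the direction seen on lengthening the chain up to compound 3 does not continue: ethyl in place of hydrogen, eight bonds along the chain from an amide-type nitrogen, turns it round with a large step (a 32-fold higher number from compound 3 to compound 4 (1.50 log units; beyond the scatter)). The number for compound 4 also ends above those of the shorter butyl-bearing compound (a 12-fold higher number from compound 1 to compound 4 (1.08 log units; beyond the scatter)) and the isobutyl-bearing compound (a 4.3-fold higher number from compound 2 to compound 4 (0.63 log units; beyond the scatter)), so among these compounds the lowest number sits at compound 3 and not at the longest chain. Nothing at hand accounts for this reversal.

Open, going by these compounds, is whether a longer chain would continue the rise, and how sharply the rise sets in past compound 3. Also open, on these data alone, is whether a chain of this length ending in an amine or a carboxylic acid would track compound 3 or compound 4.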